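The compounds below may be only part of what the source reports. "The series", "measured", "known", "first", "only" and "open" are said of these compounds alone.

Compound 1, `Cc1ccnc(/C(N)=N/NC(=S)N2CCSCC2)c1`, gives 91.6% in a functional assay on HeLa cells (Homo sapiens) for cytotoxicity, read by MTT assay, with a stated time of 72 h, tested at 100 uM; a lower number here means less inhibition of growth, a higher number more inhibition of growth at the concentration tested. Compound 2, `N/C(=N\NC(=S)N1CCSCC1)c1ccccn1`, gives 88.7% in this assay.

Among the compounds with values here, of these two numbers, compound 1 carries the higher one, but the only step between them, a number 2.9 percentage points lower from compound 1 to compound 2 (within the scatter), is within the scatter, so the two compounds cannot be told apart on growth inhibition. Both show strong inhibition at the tested concentration.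

Compound 3, `Cc1ccnc(/C(N)=N/NC(=S)N2CCCCC2)c1`, has not been measured. It differs from compound 1 in one place: piperidin-1-yl in place of thiomorpholin-4-yl on a thiocarbonyl carbon. Within the data shown here, the one measured step, from compound 1 to compound 2, concerns a change on the aromatic ring and not the ring attached to the thiocarbonyl carbon, so it does not speak directly to this exchange; it shows only that the shared core tolerates a small change without a shift beyond the scatter. Among the measured compounds shown here, no step on the thiocarbonyl side is available.

With both measured compounds at high inhibition, compound 3 is expected to stay in the same region, and the step of a number 3.6 percentage points lower from compound 1 to compound 3 (within the scatter) is estimated to lie within the scatter. The estimate for compound 3 is 88%, with a range from 70% to 97%.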

Compound 3, percent growth inhibition at one concentration: 70.8%
Beside the measured number, compound 3's estimate is 17.2 percentage points above it; measured number inside the range.
By their numbers in this assay, from the lowest: compound 3; then compounds 2 and 1 (each within the scatter of the next).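

In this assay, the exchange on the thiocarbonyl carbon is the first change among these compounds to move the number beyond the scatter, a step printed as a number 20.8 percentage points lower from compound 1 to compound 3 (beyond the scatter) in the comparison of the two rings. The group on the thiocarbonyl carbon therefore matters for growth inhibition at the tested concentration, which the earlier change on the aromatic carbon could not show, and the two groups are alike in ring size and differ in that the sulfur of thiomorpholin-4-yl is replaced by carbon in piperidin-1-yl. This is a single pair of compounds, and nothing available here says what lies behind the drop in the number.

From the compounds shown here alone, whether sulfur itself is what counts stays open, and morpholin-4-yl, with oxygen at that ring place, or piperazin-1-yl, with a second nitrogen, would speak to that. Also open, going by these compounds, is whether the same exchange gives a step of similar size on the core of compound 2, with hydrogen in place of methyl on the aromatic carbon.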